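A few compounds are considered here, and "the series" means these few. Any claim that something is new, unique, unknown or untested is made for them only; others in the source may bear on it.

Compound 1 `c1nnc2nnc(N3CCCC3)nn12` gives 24400 nM
Compound 2 `CC(Nc1nnc2nncn2n1)C(=O)O` gives 74300 nM
Compound 3 `CCCCCC(=O)N1CCN(c2nnc3nncn3n2)CC1` gives 3610 nM

These three compounds share one core and were tested in a functional assay on HL-60 cells (Homo sapiens) for inhibition, read by MTT assay, with a stated time of 72 h; a higher number here means a weaker inhibitor, a lower number a stronger inhibitor. Compound 3 stands lowest of the three numbers, so it is the strongest inhibitor here: compound 1 lies well above it, and compound 2 lies furthest away, both gaps beyond the usual scatter. Compound 3 is also the only one of the three that carries a pentylcarbonyl group on its saturated ring.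

Compound 4 `CC(=O)N1CCN(c2nnc3nncn3n2)CC1` is not yet measured. It differs from compound 3 in one place: hydrogen in place of butyl on a saturated chain carbon bound to a carbonyl carbon. Put another way, the pentylcarbonyl group of compound 3 becomes an acetyl group in compound 4.

Among the measured compounds shown here, no pair of measured compounds shows what this kind of trimming does, so the expectation rests on the fact that compound 3, with the longer chain, gives the lowest number at 3610 nM. Removing the butyl is expected to move the number upward, toward a weaker inhibitor, by a modest step that should fall beyond the scatter. Compound 4 is estimated at 12000 nM, with a range from 4000 nM to 40000 nM. The expected step of a 3.3-fold higher number from compound 3 to compound 4 (0.52 log units; beyond the scatter) reflects this estimate.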

Compound 4, half-maximal inhibitory concentration: 14700 nM
Compound 4: the middle estimate sits 1.2-fold (0.09 log units) below what was measured; the measured number falls inside the stated range.
By their numbers in this assay, from the lowest: compound 3; then compounds 4 and 1 (each within the scatter of the next); then compound 2.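

Among the compounds shown here, compounds 3 and 4 give the first direct comparison in this set, as they differ in one place only. In this assay, hydrogen in place of butyl on a saturated chain carbon bound to a carbonyl carbon, which turns pentylcarbonyl into acetyl, gives a 4.1-fold higher number from compound 3 to compound 4 (0.61 log units; beyond the scatter), a modest change toward a weaker inhibitor that is beyond the scatter. The butyl part of the chain therefore matters for the number seen with compound 3, and the acetyl group alone does not reproduce that number, although nothing measured here explains why.

With only these two chain ends compared, the compounds shown cannot tell whether the number changes gradually with an ethyl or propyl group in place of the butyl, or whether a longer chain such as heptyl would lower it further. They also leave open how the number would respond to a phenyl ring, an amine or a carboxylic acid placed on the chain, so the effect of chain length cannot yet be separated from what other groups might do there.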